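This account rests on a few compounds, and the source may have more. Where it says the series, first, only, none or still open, it means among the compounds named here.

Measured in an in vitro assay on Sf21 cells for inhibition of high affinity 3',5'-cyclic-AMP phosphodiesterase 7A (Homo sapiens), read by scintillation proximity assay, with a stated time of 30 min; a higher number here means a weaker inhibitor, a lower number a stronger inhibitor:
compound 1 `CC(=O)Nc1ccc(NC(=O)c2cn(Cc3c(F)cccc3F)c3ccc(=O)[nH]c3c2=O)cc1` gives 24 nM
compound 2 `O=C(NCc1ccncc1)c1ccc(NC(=O)c2cn(Cc3c(F)cccc3F)c3ccc(=O)[nH]c3c2=O)cc1` gives 20 nM

Among the measured compounds shown here, compound 2 has the lowest of the two numbers so far; its nearest neighbour is compound 1, and the step of a 1.2-fold lower number from compound 1 to compound 2 (0.08 log units; within the scatter) stays within the scatter. Compound 3 `CS(=O)(=O)c1ccc(NC(=O)c2cn(Cc3c(F)cccc3F)c3ccc(=O)[nH]c3c2=O)cc1` differs from compound 2 by methylsulfonyl in place of ((pyridin-4-yl)methyl)carbamoyl on an aromatic carbon. For the measured compounds named here, the only step that bears on this position is a 1.2-fold lower number from compound 1 to compound 2 (0.08 log units; within the scatter), in which a large change of the group at this place left this assay almost unmoved. A step of about a 1.5-fold higher number from compound 2 to compound 3 (0.18 log units; within the scatter) is therefore expected, no change beyond the scatter in either direction. For compound 3 the estimate in this assay is 30 nM, with a range of 10 nM to 100 nM.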

Compound 3, half-maximal inhibitory concentration: 27 nM
Compound 3: middle estimate off by 1.1-fold (0.05 log units), on the high side; measured number inside the range.
By their numbers in this assay, from the lowest: compounds 2, 1 and 3 (each within the scatter of the next).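

In this assay, methylsulfonyl replaces ((pyridin-4-yl)methyl)carbamoyl with a 1.4-fold higher number from compound 2 to compound 3 (0.13 log units; within the scatter), and replaces acetamido with a 1.1-fold higher number from compound 1 to compound 3 (0.05 log units; within the scatter). At this aromatic carbon, para to a large group, the number therefore stays within the scatter even when the six-membered aromatic ring and the hydrogen-bond donor of the compound 2 group are gone. Nothing available accounts for this insensitivity.

Still open, from the compounds shown here alone, is whether a carboxylic acid or an amine at this place would also leave the number within the scatter. Going by these compounds, a bare hydrogen at this place is an equally open case.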